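The compounds below may be only part of what the source reports. "The series", "measured", "known", "first", "only" and "open" are said of these compounds alone.

Three compounds share one core and differ only in the group carried on an aromatic carbon: compound 1 `O=C(CSc1nnnn1-c1ccccc1)N/N=c1/scc(-c2ccc(Br)cc2)n1-c1ccccc1`, compound 2 `Cc1ccc(-c2cs/c(=N/NC(=O)CSc3nnnn3-c3ccccc3)n2-c2ccccc2)cc1` and compound 3 `O=C(CSc1nnnn1-c1ccccc1)N/N=c1/scc(-c2ccc(F)cc2)n1-c1ccccc1`. In a functional assay on C6 cells (Rattus norvegicus) for cytotoxicity, read by MTT assay, with a stated time of 24 h, tested at 50 ug/mL (on this read-out higher numbers stand for a weaker effect at the one concentration tested and lower numbers for a stronger effect), compound 1 gives 32%, compound 2 gives 29.5% and compound 3 gives 43.7%. Compound 2 stands at the lowest of the three numbers, but the gap to compound 1, a number 2.5 percentage points lower from compound 1 to compound 2 (within the scatter), is within the scatter, so the two cannot be told apart; only a number 14.2 percentage points higher from compound 2 to compound 3 (beyond the scatter) and a number 11.7 percentage points higher from compound 1 to compound 3 (beyond the scatter) lie beyond it.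

Compound 4 `Cc1ccc(-c2cs/c(=N/NC(=O)CSc3nnnn3C)n2-c2ccccc2)cc1` has not yet been measured. It differs from compound 2 at one place: methyl in place of phenyl on an aromatic nitrogen. For the measured compounds named here, none of the measured steps touches this place; all three exchange the group on the aromatic carbon, which stays methyl in compound 4. Going by the values given here, nothing among the measured compounds therefore shows how this exchange moves the read-out, and the expectation in this assay is a step of no more than the scatter, in no firm direction. Compound 4 is estimated at 32%, between 15% and 52%, which corresponds to an expected a number 2.5 percentage points higher from compound 2 to compound 4 (within the scatter).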

Compound 4, a percentage reported as activity, at one concentration (the size of the read-out at that concentration, not a potency): 44.3%
The estimate for compound 4 lay 12.3 percentage points below the measured number, and the stated range covers the measured number.
By their numbers in this assay, from the lowest: compounds 2 and 1 (each within the scatter of the next); then compounds 3 and 4 (each within the scatter of the next).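

In this assay, methyl in place of phenyl on the aromatic nitrogen gives a number 14.8 percentage points higher from compound 2 to compound 4 (beyond the scatter) and so a weaker effect at the one concentration tested. For the compounds shown here, this is the first sign that the read-out responds to the group on this nitrogen and not only to the group on the aromatic carbon, and here the phenyl goes with the stronger effect. No measurement is available that would explain this step.

A single pair cannot show whether the ring or simply the larger group matters, and a benzyl group, an ethyl chain or a pyridine ring on this nitrogen would help to separate the two. On these data alone, it also remains open whether the same exchange moves the number similarly when bromo or fluoro sits on the aromatic carbon.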